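The compounds below may be only part of what the source reports. "The series", "measured", "known", "first", "only" and "open" are said of these compounds alone.

The series shares one core, seen in compound 1 `C=CCc1cc(C(C)=O)c(O)cc1OCCCCC#N`, compound 2 `CCc1cc(C(C)=O)c(O)cc1OCCCCCCC(C)(C)C#N` and compound 3 `C=CCc1cc(C(=O)CC)c(O)cc1OCCCCC#N`. In an assay on isolated protein for binding affinity to leukotriene B4 receptor 1 (Homo sapiens), tested at 1 uM (on this read-out lower numbers stand for less inhibition and higher numbers for more inhibition at the one concentration tested (going by the name of the read-out)), compound 1 gives 57%, compound 2 gives 30% and compound 3 gives 36%. Compound 3 thus stands second highest of the three numbers: its nearest neighbour is compound 2, whose value lies within the scatter of its own, while compound 1 lies beyond the scatter above it. For the measured compounds named here, the single one-point step among the measured compounds is a number 21 percentage points lower from compound 1 to compound 3 (beyond the scatter), a modest fall on methyl in place of hydrogen on a saturated chain carbon bound to a carbonyl carbon.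

Compound 4 `C=CCc1cc(C(=O)c2ccccc2)c(O)cc1OCCCCC#N` has not yet been measured. It differs from compound 3 as follows: phenyl in place of ethyl on a carbonyl carbon. The acyl group is enlarged again, from propanoyl to benzoyl. Going by the values given here, the step from compound 1 to compound 3 is the only measured step that bears on this change, and there enlarging the acyl group lowered inhibition beyond the scatter. A further decrease in this assay is therefore expected, though a single step gives little basis for its size, and compound 2, which differs in several places, cannot be compared one to one. The step is estimated at a number 12 percentage points lower from compound 3 to compound 4 (beyond the scatter). Compound 4 is expected to give 24%, in the range 5% to 45%.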

Compound 4, a percentage reported as inhibition, at one concentration (the size of the read-out at that concentration, not a potency): 5%
Compound 4: the middle estimate sits 19 percentage points above what was measured, within the range that was stated.
By their numbers in this assay, from the lowest: compound 4; then compounds 2 and 3 (each within the scatter of the next); then compound 1.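

In this assay the group on the carbonyl carbon proves to be a sensitive place: phenyl in place of ethyl gives a number 31 percentage points lower from compound 3 to compound 4 (beyond the scatter) and phenyl in place of methyl gives a number 52 percentage points lower from compound 1 to compound 4 (beyond the scatter) with nothing else in the molecule changed. Together with the earlier step of a number 21 percentage points lower from compound 1 to compound 3 (beyond the scatter) this makes an unbroken order across the three compounds that differ only here, from methyl through ethyl to phenyl, and no compound among these three goes against it, while compound 2 differs in several places and stands outside the comparison. The change from propanoyl to benzoyl, which brings in one six-membered aromatic ring, weighs far more than the earlier change from methyl to ethyl, and the data hold nothing that accounts for the fall.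

The compounds shown do not separate the effect of the aromatic ring from that of the added heavy atoms, which a cyclopropyl or cyclohexyl group on the carbonyl carbon would address. Also open, going by these compounds, is whether a group smaller than methyl, such as hydrogen, or an amine on the carbonyl carbon would hold or raise inhibition on the shared core.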